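Fluoro in place of chloro in a growth inhibitor

The source may hold more compounds than are shown below. What is called first, only, known or untested is meant among the compounds shown, and "the series" means these compounds.

- Compound 1 `O=S(=O)(/C=C/c1ccc(C(F)(F)F)cc1F)Cc1ccc(Nc2ncnc3cc(Cl)ccc23)cc1` gives > 100000 nM as a limit
- Compound 2 `O=S(=O)(/C=C/c1ccc(F)cc1Cl)Cc1ccc(Nc2ncnc3cc(Cl)ccc23)cc1` gives 37000 nM as a number

In a functional assay on DU-145 cells (Homo sapiens) for inhibition (on this read-out higher numbers stand for weaker inhibition of growth and lower numbers for stronger inhibition of growth), compound 1 has > 100000 nM as its reading, which is a limit and not a number. Going by the values given here, compound 2 stands at 37000 nM as the only true number so far. Compound 3 `O=S(=O)(/C=C/c1ccc(F)cc1F)Cc1ccc(Nc2ncnc3cc(Cl)ccc23)cc1` carries fluoro in place of chloro on an aromatic carbon and so turns 2-chloro-4-fluorophenyl into 2,4-difluorophenyl. Among the compounds with values here, only one measured step bears on this, and only loosely. That step is an at least 2.7-fold lower number from compound 1 to compound 2 (0.43 log units; beyond the scatter) and it swaps a whole substituted phenyl group, with one end of its size resting on a limit. It therefore gives no firm direction for a single exchange of chloro for fluoro. The expected change is a 1.1-fold higher number from compound 2 to compound 3 (0.03 log units; within the scatter) and no step beyond the usual scatter is expected in this assay for this exchange. Compound 3 is therefore expected at 40000 nM (estimated range 15000 nM to 100000 nM).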

Compound 3, concentration for 50% growth inhibition: > 100000 nM
Compound 3 ended at the assay's limit; the forecaster's own chance of this, stated with the estimate: 20%; at least 2.5-fold (0.39 log units) between middle value and limit.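

The earlier swap replaced a whole substituted phenyl group, whereas this one changes a single atom on the ring: in this assay, an at least 2.7-fold higher number from compound 2 to compound 3 (0.43 log units; beyond the scatter). So at this position, fluoro in place of chloro weakens growth inhibition beyond the usual scatter, leaving compound 2 as the only compound of the three with a true number, 37000 nM. The full size of this loss stays unknown, and the step between compound 1 and compound 3 cannot be read at all, because the readings involved rest on a limit: the limit of > 100000 nM in this assay, at which 2 of the 3 values shown sit.

On these data alone, it remains open whether a larger halogen such as bromo, or a methyl or methoxy group, would do better than chloro at this position. As far as these compounds go, it is also open whether chloro would give a similar gain with trifluoromethyl in place of the other fluoro.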